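Undrawn ring stereocentre: compound 3 to compound 4

This account rests on a few compounds, and the source may have more. Where it says the series, first, only, none or still open, it means among the compounds named here.

Measured in an ADME assay on Vero cells (Chlorocebus sabaeus) for cytotoxicity; on this read-out higher numbers stand for lower toxicity in this test and lower numbers for higher toxicity in this test:
- compound 1 `CON=C1CCC(CN2CCN(c3nc(=O)c4cc(C(F)(F)F)cc([N+](=O)[O-])c4s3)CC2)CC1` gives > 64 ug/mL
- compound 2 `CON=C1CCC(CN2CCN(c3nc(=O)c4cc(C(F)(F)F)cc([N+](=O)[O-])c4s3)C[C@@H]2C)CC1` gives > 64 ug/mL
- compound 3 `CCON=C1CCC(CN2CCN(c3nc(=O)c4cc(C(F)(F)F)cc([N+](=O)[O-])c4s3)C[C@@H]2C)CC1` gives > 64 ug/mL

Each entry is a limit of the assay and not a number.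

Compound 3 has no number in this assay, and its > 64 ug/mL is a limit. The rest of the series stands the same way: the limit of > 64 ug/mL in this assay, at which 3 of the 3 values shown sit.

Compound 4 `CCON=C1CCC(CN2CCN(c3nc(=O)c4cc(C(F)(F)F)cc([N+](=O)[O-])c4s3)CC2C)CC1` has the same atoms and bonds as compound 3. The difference is the two compounds have the same atoms and bonds; at least one stereo element is drawn with a configuration in one of them and without one in the other: 1 of 3 stereo elements differ; a stereocentre at a saturated ring carbon is drawn S in compound 3 and without a configuration in compound 4.

Among the compounds with values here, two measured steps bear on this change, and neither has a readable size. The first, a step that the two limits leave unreadable from compound 1 to compound 2, is methyl in place of hydrogen on a saturated ring carbon. The second, a step that the two limits leave unreadable from compound 2 to compound 3, is methyl in place of hydrogen on a saturated chain carbon bound to an oxygen on an unsaturated carbon. Neither gives a measured size to set against a change in drawn configuration. No step beyond the scatter is therefore expected, and no direction can be given.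

The expected step is a step that the limit leaves unreadable from compound 3 to compound 4. For compound 4 the estimated value is 80 ug/mL, with an expected range from 40 ug/mL to 160 ug/mL, and a report of only a limit is the likely outcome.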

Compound 4, half-maximal cytotoxic concentration: > 64 ug/mL
Compound 4: a limit, no number; the forecaster's own chance of this, stated with the estimate: 90%; the middle value lies beyond the limit too.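

Compound 3 and compound 4 give no readable step in this assay, because each entry is a limit and not a number: the limit of > 64 ug/mL in this assay, at which 4 of the 4 values shown sit.

The compounds shown leave open whether the configuration drawn at the saturated ring carbon has any bearing on the read-out in this assay, and where the true value of any of these compounds lies.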